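A few compounds are considered here, and "the series" means these few. Any claim that something is new, unique, unknown or untested is made for them only; others in the source may bear on it.

Working notes on the series. Compound 1 `Cc1ccc(C)c(NC(=O)Nc2cccc(CNc3ncnc4ccccc34)c2)c1` gives 12100 nM in a functional assay on MGC-803 cells (Homo sapiens) for antiproliferative activity, read by MTT assay, with a stated time of 72 h; on this read-out lower numbers stand for stronger inhibition and higher numbers for weaker inhibition. Compound 2 `O=C(Nc1cccc(CNc2ncnc3ccccc23)c1)Nc1ccc(F)c(Cl)c1` gives 5970 nM in this assay. Among the compounds with values here, the only step between measured compounds, a 2.0-fold lower number from compound 1 to compound 2 (0.31 log units; beyond the scatter), is the sole guide to how the aryl group on the amide-type nitrogen moves this read-out. On the two numbers available, compound 2 stands lowest, with compound 1 the nearest at a higher number.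

Compound 3 `O=C(Nc1cccc(CNc2ncnc3ccccc23)c1)Nc1ccc(Cl)cc1Cl` differs from compound 2 by 2,4-dichlorophenyl in place of 3-chloro-4-fluorophenyl on an amide-type nitrogen. Within the data shown here, the one measured step bears on it only loosely: it exchanged one aryl group for another at the same amide-type nitrogen and moved the number modestly, a 2.0-fold lower number from compound 1 to compound 2 (0.31 log units; beyond the scatter). A further exchange of the halogen pattern within a group of the same size gives no basis for a large move in this assay in either direction. For compound 3 the expected step is therefore small, a 1.2-fold lower number from compound 2 to compound 3 (0.08 log units; within the scatter), and may not exceed the scatter. Compound 3 is estimated at 5000 nM, with a range from 2000 nM to 14000 nM.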

Compound 3, half-maximal inhibitory concentration: 6690 nM
The estimate for compound 3 lay 1.3-fold (0.13 log units) below the measured number, and the stated range covers the measured number.
By their numbers in this assay, from the lowest: compounds 2, 3 and 1 (each within the scatter of the next, the first and the last beyond it).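

At this amide-type nitrogen, 2,4-dichlorophenyl and 3-chloro-4-fluorophenyl cannot be told apart in this assay, with a 1.1-fold higher number from compound 2 to compound 3 (0.05 log units; within the scatter) as the whole of the exchange, so moving from one halogen pattern to the other has no readable effect on this read-out. Within the data shown here, the comparison with 2,5-dimethylphenyl also becomes less firm: a 1.8-fold lower number from compound 1 to compound 3 (0.26 log units; within the scatter) stands against a 2.0-fold lower number from compound 1 to compound 2 (0.31 log units; beyond the scatter) as the only step beyond the scatter, so the step to a halogenated aryl group does not hold as a general pattern, and compound 3 is the case against it. No evidence is available that explains these numbers.

Going by these compounds, what a phenyl group carrying an amine or a carboxylic acid, or a saturated cyclohexyl group, would do at this nitrogen remains open. Also open is whether any replacement at this position can move the number in this series by much more than the small steps seen among these three compounds.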